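The compounds below may be only part of what the source reports. "The series", "measured", "known", "first", "only" and "open" are said of these compounds alone.

Compound 1 `O=S(=O)(CC1=NCCO1)C1C(c2ccc(Cl)cc2)=NOC1c1ccc(Cl)cc1` and compound 2 `COc1ccc(C2=NOC(c3ccc(C)cc3)C2S(=O)(=O)CC2=NCCO2)cc1` share a sulfonyl-linked arrangement, but the difference between their two cores is not broken down here. In a functional assay, tested at 75 ug/mL (a higher number here means a stronger effect of the compound at the concentration tested, a lower number a weaker effect), compound 1 is reported as "not active" (no number reported), while compound 2 gives 66.6%. Compound 3 `COc1ccc(C2=NOC(c3ccc(C)cc3)C2S(=O)(=O)CC2=NCCS2)cc1` differs from compound 2 by a group of 5 heavy atoms (3 carbon, 1 nitrogen, 1 sulfur; one five-membered non-aromatic ring with 2 hetero atoms) in place of a group of 5 heavy atoms (3 carbon, 1 nitrogen, 1 oxygen; one five-membered non-aromatic ring with 2 hetero atoms), on a saturated chain carbon bound to a sulfonyl sulfur; in this assay compound 3 gives 49.7%, and the step is a number 16.9 percentage points lower from compound 2 to compound 3 (beyond the scatter). Compound 4 `O=S(=O)(CC1=NCCS1)C1C(c2ccc(Cl)cc2)=NOC1c1ccc(Cl)cc1` arises from compound 1 by the same change, (a group of 5 heavy atoms (3 carbon, 1 nitrogen, 1 sulfur; one five-membered non-aromatic ring with 2 hetero atoms) in place of a group of 5 heavy atoms (3 carbon, 1 nitrogen, 1 oxygen; one five-membered non-aromatic ring with 2 hetero atoms), on a saturated chain carbon bound to a sulfonyl sulfur), made at a place described in the same words. Because compound 1 is reported as "not active" (no number reported) and the same change gave a number 16.9 percentage points lower from compound 2 to compound 3 (beyond the scatter), compound 4 is expected to stay at or near the inactive end of this assay. For compound 4 the estimated read-out is 8%, expected to fall between 0% and 25%.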

Compound 4, a percentage reported as activity, at one concentration (the size of the read-out at that concentration, not a potency): "not active" (no number reported)
Compound 4 has no reported number here; there is nothing to compare the estimate with.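

Compound 1 and compound 4 are both reported as " "not active" (no number reported) " in effect without a number, so no step can be read between them. The compounds shown leave open how large this ring change is on the core of compound 1. No measured property bears on this result.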